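This account rests on a few compounds, and the source may have more. Where it says the series, first, only, none or still open, it means among the compounds named here.

Measured so far: compound 1 `O=C(Nc1ccccc1)Nc1cccc(CNc2nccnc2Cl)c1` gives 16300 nM and compound 2 `O=C(Nc1ccc(Cl)cc1)Nc1cccc(CNc2nccnc2Cl)c1` gives 4980 nM in a functional assay on MGC-803 cells (Homo sapiens) for antiproliferative activity, read by MTT assay, with a stated time of 48 h; on this read-out higher numbers stand for weaker inhibition and lower numbers for stronger inhibition.

Compound 2 has the lowest of the two numbers, the step being a 3.3-fold lower number from compound 1 to compound 2 (0.51 log units; beyond the scatter). Compound 3 `O=C(Nc1cccc(CNc2nccnc2Cl)c1)NC1CCCC1` differs from compound 2 by cyclopentyl in place of 4-chlorophenyl on an amide-type nitrogen. Going by the values given here, only one measured step exists, and it concerns the chlorine on the ring that now leaves entirely, so it bears only loosely on this change; the gain it brought is likely given back, and the ring-to-ring swap itself is untested. Compound 3 is therefore expected to show a higher number, a 2.4-fold higher number from compound 2 to compound 3 (0.38 log units; beyond the scatter), with an estimate of 12000 nM (range 3000 nM to 45000 nM).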

Compound 3, half-maximal inhibitory concentration: 23400 nM
Estimate against measurement, compound 3: 2.0-fold (0.29 log units) below; the range from low to high includes it.
By their numbers in this assay, from the lowest: compound 2; then compounds 1 and 3 (each within the scatter of the next).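

In this assay, cyclopentyl in place of 4-chlorophenyl on the amide-type nitrogen gives a 4.7-fold higher number from compound 2 to compound 3 (0.67 log units; beyond the scatter). Cyclopentyl in place of the unsubstituted phenyl gives a 1.4-fold higher number from compound 1 to compound 3 (0.16 log units; within the scatter), so this saturated ring and the plain phenyl cannot be told apart here, and only the chlorinated ring of compound 2 stands out. No evidence on hand explains this difference.

Still open, going by these compounds, is how a methoxy group or an amine in place of the chlorine of compound 2 would read. Also open, on these data alone, is how a longer chain, such as butyl, would compare on this nitrogen.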